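Working notes: from 4-chlorobenzyl to 2-nitrobenzyl

This account rests on a few compounds, and the source may have more. Where it says the series, first, only, none or still open, it means among the compounds named here.

- compound 1 `Clc1ccc(COc2ccc(OCCOCCNC3CCCCC3)cc2)cc1` gives 2650 nM
- compound 2 `Clc1ccc(COc2ccc(OCCOCCNC3CCCC3)cc2)cc1` gives 7670 nM

In a functional assay on SK-OV-3 cells (Homo sapiens) for inhibition, read by CCK-8 assay, with a stated time of 70 h (on this read-out higher numbers stand for weaker inhibition and lower numbers for stronger inhibition), compound 1 holds the lower of the two numbers at 2650 nM. Compound 3 `O=[N+]([O-])c1ccccc1COc1ccc(OCCOCCNC2CCCCC2)cc1` departs from it by 2-nitrophenyl in place of 4-chlorophenyl on a saturated chain carbon bound to an oxygen on an aromatic ring. Within the data shown here, the only measured step, a 2.9-fold higher number from compound 1 to compound 2 (0.46 log units; beyond the scatter), is modest and lies on the amine nitrogen, not at this place, so it suggests a size only. No measurement covers this change, so direction is weakly supported. A modest step to a higher number in this assay is expected. The estimated step is a 1.5-fold higher number from compound 1 to compound 3 (0.18 log units; within the scatter). For compound 3 the estimated value is 4000 nM, with an expected range of 1500 nM to 11000 nM.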

Compound 3, half-maximal inhibitory concentration: 2880 nM
Compound 3: the middle estimate sits 1.4-fold (0.14 log units) above what was measured; the range from low to high includes it.
By their numbers in this assay, from the lowest: compounds 1 and 3 (each within the scatter of the next); then compound 2.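

Replacing 4-chlorophenyl with 2-nitrophenyl on a saturated chain carbon bound to an oxygen on an aromatic ring gives a 1.1-fold higher number from compound 1 to compound 3 (0.04 log units; within the scatter) in this assay and so does not separate the two compounds. This place therefore accepts a larger group bringing 2 hydrogen-bond acceptors with no change beyond the scatter. No supporting measurement bears on why the two groups read alike.

From the compounds shown here alone, whether unsubstituted phenyl, 4-nitrophenyl or a pyridine ring would also read alike here remains open. So does whether cyclopentyl in place of cyclohexyl on the amine nitrogen gives a similar step alongside 2-nitrophenyl.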